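Swapping fluoro for dimethylamino in a growth inhibitor

The source may hold more compounds than are shown below. What is called first, only, known or untested is meant among the compounds shown, and "the series" means these compounds.

Within the data shown here, in a functional assay on CCRF-CEM cells (Homo sapiens) for inhibition (on this read-out lower numbers stand for stronger inhibition of growth and higher numbers for weaker inhibition of growth), compound 3 `NS(=O)(=O)c1ccc(/C=C/c2ccc(F)cc2)cc1` gives 62000 nM, the highest number of the three measured so far, which makes it the weakest growth inhibitor among them. Compound 1 `COc1cc(/C=C/c2ccc(S(N)(=O)=O)cc2)cc(OC)c1` gives 19900 nM and compound 2 `NS(=O)(=O)c1ccc(/C=C/c2ccc(O)c(O)c2)cc1` gives 4790 nM, and both gaps to compound 3 lie beyond the scatter. Compound 4 `CN(C)c1ccc(/C=C/c2ccc(S(N)(=O)=O)cc2)cc1` has dimethylamino in place of fluoro on an aromatic carbon. Among the measured compounds shown here, no measured pair shows this swap, so any forecast is rough. Compound 3 already stands at the top of the numbers with 62000 nM, so a move down seems likelier than a move up. The expected change is a 4.4-fold lower number from compound 3 to compound 4 (0.65 log units; beyond the scatter), towards stronger inhibition. For compound 4 the estimated value is 14000 nM, with an expected range from 3500 nM to 50000 nM.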

Compound 4, concentration for 50% growth inhibition: 46000 nM
The estimate for compound 4 lay 3.3-fold (0.52 log units) below the measured number; low and high end bracket the measured number.
By their numbers in this assay, from the lowest: compound 2; then compound 1; then compounds 4 and 3 (each within the scatter of the next).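

In this assay dimethylamino in place of fluoro on an aromatic carbon gives a 1.3-fold lower number from compound 3 to compound 4 (0.13 log units; within the scatter) and so leaves the number within the scatter. This first single-place step shows that, at this place para to a large group, the three-heavy-atom dimethylamino and the single fluorine read alike, even though only dimethylamino counts a hydrogen-bond acceptor. Nothing measured here explains this result.
From the compounds shown here alone, whether a primary amine, a carboxylic acid or a longer chain at this place would move the number beyond the scatter stays open.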